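Hydroxy to hydrogen on the saturated ring: compound 4

The source may hold more compounds than are shown below. What is called first, only, known or untested is meant among the compounds shown, and "the series" means these compounds.

Measured so far:
compound 1 `CC(=O)c1ccc(NC(=O)C2CC(O)CN2S(=O)(=O)c2ccc([N+](=O)[O-])cc2)cc1`: 58.7%
compound 2 `CC(=O)c1ccc(NC(=O)C2CCCN2S(=O)(=O)c2ccc([N+](=O)[O-])cc2)cc1`: 24.3%
compound 3 `CC(=O)c1ccc(NC(=O)C2CC(O)CN2S(=O)(=O)c2ccccc2)cc1`: 49.8%

All three numbers come from a functional assay for inhibition, read by spectrophotometry, with a stated time of 20 min, tested at 3 mg/mL; on this read-out lower numbers stand for a weaker effect and higher numbers for a stronger effect at the one concentration tested. Compound 3 stands second highest of the three: the step of a number 8.9 percentage points lower from compound 1 to compound 3 (within the scatter) is within the scatter, while compound 2 lies well below both, beyond the scatter.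

Compound 4 `CC(=O)c1ccc(NC(=O)C2CCCN2S(=O)(=O)c2ccccc2)cc1` differs from compound 3 by hydrogen in place of hydroxy on a saturated ring carbon. One measured step covers this very change, and it was large: a number 34.4 percentage points lower from compound 1 to compound 2 (beyond the scatter). A drop of similar size in this assay is therefore expected here, estimated as a number 31.8 percentage points lower from compound 3 to compound 4 (beyond the scatter). On that basis compound 4 is expected to give 18%, with a range from 5% to 35%.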

Compound 4, a percentage reported as inhibition, at one concentration (the size of the read-out at that concentration, not a potency): 29.2%
Compound 4: the middle estimate sits 11.2 percentage points below what was measured, within the range that was stated.
By their numbers in this assay, from the lowest: compounds 2 and 4 (each within the scatter of the next); then compounds 3 and 1 (each within the scatter of the next).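

The loss on removing the hydroxy from this saturated ring carbon now recurs on the core without nitro, with a number 20.6 percentage points lower from compound 3 to compound 4 (beyond the scatter), so it is not confined to one core: the same change on two cores in this assay, a number 34.4 percentage points lower (beyond the scatter) from compound 1 to compound 2 and a number 20.6 percentage points lower (beyond the scatter) from compound 3 to compound 4, 13.8 percentage points apart, within the scatter of two such steps. With the hydroxy absent, hydrogen in place of nitro stays within the scatter, at a number 4.9 percentage points higher from compound 2 to compound 4 (within the scatter), as it did with the hydroxy present: the same change on two cores in this assay, a number 8.9 percentage points lower (within the scatter) from compound 1 to compound 3 and a number 4.9 percentage points higher (within the scatter) from compound 2 to compound 4, 13.8 percentage points apart, within the scatter of two such steps. Across these four compounds, only the hydroxy change gives steps beyond the scatter.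

Still open, as far as these compounds go, is how an amine or a methoxy on this ring carbon would compare with the hydroxy. Also open, from the compounds shown here alone, is how a carboxylic acid in place of the nitro on the aromatic carbon would read.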